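The source may report more compounds than this note shows. Statements on the series, on what has been measured and on what is new or still open speak of the compounds shown alone.

In a functional assay on PC-3 cells (Homo sapiens) for antiproliferative activity, read by MTT assay, with a stated time of 72 h (on this read-out lower numbers stand for stronger inhibition and higher numbers for weaker inhibition), compound 1 (`CCCCCCCCCNC[C@@H]1OC[C@H](N)[C@H]1O`) gives 7650 nM. Compound 2 (`CCCCCCCNC[C@@H]1OC[C@H](N)[C@H]1O`) reaches only a limit, > 128000 nM, so it has no exact number. Compound 3 (`CCCCCCCCCCCNC[C@@H]1OC[C@H](N)[C@H]1O`) differs from compound 2 by butyl in place of hydrogen on a saturated chain carbon, seven bonds along the chain from an amine nitrogen. For the measured compounds named here, one measured step bears on this change: an at least 16-fold higher number from compound 1 to compound 2 (1.22 log units; beyond the scatter). That large step takes ethyl away at the same place where compound 3 gains butyl, so the opposite direction, towards a lower number, is expected here. Going by the values given here, no measured compound shows what the chain beyond ethyl adds, so the expectation stays in the region of compound 1 at 7650 nM. The expected step is large: an at least 28-fold lower number from compound 2 to compound 3 (1.45 log units; beyond the scatter). Compound 3 is estimated at 4500 nM, with an expected range from 1500 nM to 15000 nM.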

Compound 3, half-maximal inhibitory concentration: 10000 nM
The estimate for compound 3 lay 2.2-fold (0.35 log units) below the measured number; the range from low to high includes it.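

Butyl in place of hydrogen on a saturated chain carbon, seven bonds along the chain from an amine nitrogen, gives an at least 12-fold lower number from compound 2 to compound 3 (1.10 log units; beyond the scatter) in this assay, so the large step seen earlier with ethyl also appears with this longer group. Ethyl in place of hydrogen on a saturated chain carbon, nine bonds along the chain from an amine nitrogen, gives a 1.3-fold higher number from compound 1 to compound 3 (0.12 log units; within the scatter), so the chain beyond that of compound 1 brings no change that can be told from the scatter. The larger step remains a bound, since compound 2 has only a limit and no exact number: the limit of > 128000 nM in this assay, at which 1 of the 3 values shown sits.

Going by these compounds, whether this level holds for a chain longer than that of compound 3 remains open. So does the effect of a phenyl group in place of butyl.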